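Bromo substitution on two cores of a diarylpyrimidine series

The source may hold more compounds than are shown below. What is called first, only, known or untested is meant among the compounds shown, and "the series" means these compounds.

Of the compounds shown here, three have been measured in a physicochemical assay for lipophilicity; a higher number here means a more lipophilic compound, a lower number a more polar compound. Compound 1 `Cc1cc(C#N)cc(C)c1Oc1ccnc(Nc2ccc(C#N)cc2)n1` gives 1.64. Compound 2 `Cc1cccc(C)c1Nc1ccnc(Nc2ccc(C#N)cc2)n1` gives 1.74, and compound 3 `Cc1cc(Br)cc(C)c1Nc1ccnc(Nc2ccc(C#N)cc2)n1` gives 1.79. Compound 1 shows the lowest of the three numbers, but its gaps to compound 2 and to compound 3 both lie within the scatter, so no order is claimed among them.

Compound 2 and compound 3 differ in one place: bromo in place of hydrogen on an aromatic carbon. The step of a number 0.05 log units higher from compound 2 to compound 3 (within the scatter) is within the scatter. Compound 1 and compound 2 have different cores; the difference between the two cores is not broken down here.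

Compound 4 `Cc1cc(C#N)cc(C)c1Oc1nc(Nc2ccc(C#N)cc2)ncc1Br` is not yet measured in this assay. It differs from compound 1 by bromo in place of hydrogen on an aromatic carbon. This is the same kind of change as that from compound 2 to compound 3, not the same change: in compound 3 the bromo sits on an aromatic carbon of a six-membered aromatic ring of carbon only, meta to two methyl groups and para to a large group, whereas in compound 4 it sits on an aromatic carbon of a six-membered aromatic ring with 2 nitrogen, ortho to a large group, two atoms from the ring nitrogen and para to a (4-cyanophenyl)amino group.

The step of a number 0.26 log units higher from compound 1 to compound 4 (within the scatter) is expected to be small and, like a number 0.05 log units higher from compound 2 to compound 3 (within the scatter), close to the scatter, resting only on that one measured step. Compound 4 is therefore estimated at 1.9, with a range from 1.6 to 2.2.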

Compound 4, partition coefficient: 1.82
Estimate against measurement, compound 4: 0.08 log units above; the measured number falls inside the stated range.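

In this assay, bromo in place of hydrogen on an aromatic carbon gives a number 0.18 log units higher from compound 1 to compound 4 (within the scatter) on one core and a number 0.05 log units higher from compound 2 to compound 3 (within the scatter) on the other, so on both cores shown the change stays inside what repeated measurements would scatter by. This supports carrying the change between these two cores only in a limited sense: in each of the two pairs the number stays within the scatter, even though the bromo sits on a six-membered aromatic ring of carbon only in compound 3 and on a six-membered aromatic ring with 2 nitrogen in compound 4. It does not show that the two steps are equal, that either differs from zero, or that the place of the bromo is without consequence, since each core contributes a single pair and both steps lie within the scatter, and no measurement on hand bears on the reason for the size of either step.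

The compounds shown leave open whether any change at this aromatic carbon gives a step beyond the scatter, for instance an amine, a carboxylic acid or a longer chain in place of the hydrogen. They also leave open how the same bromo behaves on the ring with 2 nitrogen of the core of compound 2.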